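Methoxy for Chloro on the Benzyl Amide

The source may report more compounds than this note shows. Statements on the series, on what has been measured and on what is new or still open speak of the compounds shown alone.

Of the three measured compounds, compound 3 `N=C(N)Nc1cccc(C(=O)NCC(=O)N[C@@H](CC(=O)O)C(=O)NCc2ccc(Cl)cc2)c1` gives the largest number in an assay on a protein complex for binding affinity to integrin alpha-5/beta-1 (Homo sapiens), read by ELISA, with a stated time of 1 h (a higher number here means a weaker inhibitor, a lower number a stronger inhibitor), with 48 nM, though its gap to compound 1 `N=C(N)Nc1cccc(C(=O)NCC(=O)N[C@@H](CC(=O)O)C(=O)NCc2ccccc2)c1`, which gives 31 nM, lies within the scatter, as a 1.5-fold higher number from compound 1 to compound 3 (0.19 log units; within the scatter) shows. Compound 2 `C[C@H](NC(=O)[C@H](CC(=O)O)NC(=O)CNC(=O)c1cccc(NC(=N)N)c1)c1ccccc1` gives 20 nM; the step of a 2.4-fold higher number from compound 2 to compound 3 (0.38 log units; beyond the scatter) is modest but beyond the scatter, while a 1.6-fold lower number from compound 1 to compound 2 (0.19 log units; within the scatter) stays within it. Compound 4 `COc1ccc(CNC(=O)[C@H](CC(=O)O)NC(=O)CNC(=O)c2cccc(NC(=N)N)c2)cc1` differs from compound 3 by methoxy in place of chloro on an aromatic carbon. Among the measured compounds shown here, no measured step exchanges one substituent for another on this ring; the only step touching it, a 1.5-fold higher number from compound 1 to compound 3 (0.19 log units; within the scatter), stayed within the scatter, so no shift beyond the scatter is expected, a 1.2-fold lower number from compound 3 to compound 4 (0.08 log units; within the scatter). Compound 4 is therefore estimated at 40 nM, within a range from 15 nM to 110 nM.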

Compound 4, half-maximal inhibitory concentration: 40 nM
The estimate for compound 4 equals the measured number at the digits printed; low and high end bracket the measured number.
By their numbers in this assay, from the lowest: compounds 2, 1, 4 and 3 (each within the scatter of the next, the first and the last beyond it).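

At this aromatic carbon in this assay, exchanging one substituent for another, methoxy for chloro, gives a 1.2-fold lower number from compound 3 to compound 4 (0.08 log units; within the scatter). Methoxy in place of hydrogen gives a 1.3-fold higher number from compound 1 to compound 4 (0.11 log units; within the scatter), so, like chloro, methoxy stays within the scatter of hydrogen here. Against 1-phenylethyl, 4-methoxybenzyl gives a 2.0-fold higher number from compound 2 to compound 4 (0.30 log units; within the scatter), which stays within the scatter, whereas 4-chlorobenzyl gives a 2.4-fold higher number from compound 2 to compound 3 (0.38 log units; beyond the scatter), which lies just beyond it. No evidence is available that bears on these results. As far as these compounds go, whether an amine or a carboxylic acid on this carbon would leave the number equally unmoved remains open.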